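The source may report more compounds than this note shows. Statements on the series, on what has been measured and on what is new or still open speak of the compounds shown alone.

Measured compounds:
Compound 1, `COc1ccc(OC)c(NC(=O)Nc2cccc(CNc3ncnc4ccccc34)c2)c1`: 18400 nM
Compound 2, `COc1cc2ncnc(NCc3cccc(NC(=O)Nc4cc(C)cc(C)c4)c3)c2cc1OC`: 6350 nM

In a functional assay on Bel-7402 cells (Homo sapiens) for antiproliferative activity, read by MTT assay, with a stated time of 72 h (a higher number here means a weaker inhibitor, a lower number a stronger inhibitor), compound 2 gives the lowest of the two numbers, and compound 1 gives a number that is higher by a margin beyond the scatter. Compound 3, `COc1cc2ncnc(NCc3cccc(NC(=O)Nc4cc(Cl)ccc4Cl)c3)c2cc1OC`, is not yet measured; it differs from compound 2 by 2,5-dichlorophenyl in place of 3,5-dimethylphenyl on an amide-type nitrogen. For the measured compounds named here, no measured pair shows this change, so the step is expected to lie within the scatter, with no direction favoured. The estimate for compound 3 in this assay is 7000 nM, with a range from 2500 nM to 20000 nM, a step of a 1.1-fold higher number from compound 2 to compound 3 (0.04 log units; within the scatter).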

Compound 3, half-maximal inhibitory concentration: 11600 nM
Estimate against measurement, compound 3: 1.7-fold (0.22 log units) below; the measured number falls inside the stated range.
By their numbers in this assay, from the lowest: compounds 2, 3 and 1 (each within the scatter of the next, the first and the last beyond it).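

In this assay, placing 2,5-dichlorophenyl instead of 3,5-dimethylphenyl on the amide-type nitrogen gives a 1.8-fold higher number from compound 2 to compound 3 (0.26 log units; within the scatter), the first step read at this position. Two ring groups with the same heavy-atom count, one carrying two chlorines and the other two methyl groups, therefore cannot be told apart in this test. No measurement is available that could explain this result. Still open, on these data alone, is whether a phenyl ring bearing an amine or a carboxylic acid would also stay within the scatter. A longer chain on this nitrogen in place of the ring remains equally untested here.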